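The compounds below may be only part of what the source reports. "The series", "measured", "known", "first", "only" and "open" are said of these compounds alone.

Measured so far in a physicochemical assay for solubility, in phosphate buffer, at pH 4; a higher number here means a more soluble compound, a lower number a less soluble compound:
- compound 1 `OC[C@@H]1[C@@H](O)[C@H](O)[C@@H](O)CN1CCCCCCOc1cc(F)ccc1F` gives 296000 nM
- compound 2 `OC[C@@H]1[C@@H](O)[C@H](O)[C@@H](O)CN1CCCCCCOc1cccc(C(F)(F)F)c1` gives 281000 nM

Compound 1 at 296000 nM and compound 2 at 281000 nM lie within the scatter of each other, so compound 1 does not stand apart on these numbers. Compound 3 `COc1ccccc1OCCCCCCN1C[C@H](O)[C@@H](O)[C@H](O)[C@H]1CO` has not yet been measured. It keeps the shared core and the chain of compound 1 and carries 2-methoxyphenyl in place of 2,5-difluorophenyl on an oxygen on a saturated carbon. Within the data shown here, no measured pair differs in only one place, so the data give no direct reading of such a change. Among the measured compounds shown here, the only guide is that the two measured compounds, with different aromatic ends, give values within the scatter of each other. On that basis, no step beyond the scatter is expected in this assay, in either direction. The expected 1.0-fold lower number from compound 1 to compound 3 (0.01 log units; within the scatter) would stay within that scatter. Compound 3 is estimated at 290000 nM, with an expected range from 170000 nM to 450000 nM in this estimate.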

Compound 3, solubility: 286000 nM
For compound 3 the middle estimate is 1.0-fold (0.01 log units) above the measured one; measured number inside the range.
By their numbers in this assay, from the lowest: compounds 2, 3 and 1 (each within the scatter of the next).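

Among these compounds, the first change in one place at this position, 2-methoxyphenyl in place of 2,5-difluorophenyl on an oxygen on a saturated carbon, reads in this assay as a 1.0-fold lower number from compound 1 to compound 3 (0.01 log units; within the scatter) and so gives a direct comparison of a kind that no other measured pair offers. The group that enters carries 1 hydrogen-bond acceptor and the group that leaves carries none, and it has oxygen where the other has fluorine, yet this exchange leaves the number within the scatter. Nothing in the available data accounts for this result.

All the aromatic ends shown are uncharged, so the compounds leave open whether an amine or a carboxylic acid on the phenyl ring would also stay within the scatter of compound 1 in this assay. The chain is the same in all of them as well, so they also leave open what a shorter or a longer chain would do to the number, with the shared core and the 2-methoxyphenyl end of compound 3 held in place.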